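Notes on the acyl change from compound 2 to compound 3

The compounds below may be only part of what the source reports. "The series", "measured", "known", "first", "only" and "open" are said of these compounds alone.

In a functional assay on A2780 cells (Homo sapiens) for antiproliferative activity, read by CellTiter-Glo, with a stated time of 4 days (on this read-out lower numbers stand for stronger inhibition and higher numbers for weaker inhibition), compound 1 `O=C(Nc1ccc(CN2C(=O)c3ccccc3C2=O)cc1)[C@H]1C[C@@H]1c1cccnc1` gives (27 nM). Compound 2 `C[C@H](NC(=O)C1CCOCC1)c1ccc(NC(=O)[C@H]2C[C@@H]2c2cccnc2)cc1` gives (3 nM), the lower of the two numbers and beyond the scatter from compound 1. Compound 3 `C[C@H](NC(=O)c1ncccn1)c1ccc(NC(=O)[C@H]2C[C@@H]2c2cccnc2)cc1` is not yet measured and carries this change: pyrimidin-2-yl in place of oxan-4-yl on a carbonyl carbon with pyrimidin-2-yl in place of oxan-4-yl on a carbonyl carbon. Going by the values given here, no measured pair shows this change, so the expectation starts from compound 2 (3 nM). In this assay the expected step of a 1.7-fold higher number from compound 2 to compound 3 (0.22 log units; within the scatter) is towards a slightly higher number, within the scatter. The estimate for compound 3 is 5 nM with an expected range from 1.5 nM to 18 nM in this measurement.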

Compound 3, half-maximal inhibitory concentration: 14 nM
For compound 3 the middle estimate is 2.8-fold (0.45 log units) below the measured one; low and high end bracket the measured number.
By their numbers in this assay, from the lowest: compound 2; then compounds 3 and 1 (each within the scatter of the next).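

In this assay pyrimidin-2-yl in place of oxan-4-yl on a carbonyl carbon gives a 4.7-fold higher number from compound 2 to compound 3 (0.67 log units; beyond the scatter) and shows that this position responds to the identity of the ring, even though both groups have 6 heavy atoms. The change is modest and rests on one pair. Nothing at hand accounts for the step.

The compounds shown leave open whether the aromatic ring or its nitrogen atoms carry the step. Phenyl or pyridin-2-yl on the same carbonyl carbon would separate the two.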